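The compounds below may be only part of what the source reports. "The series", "measured", "known", "first", "only" and "open" are said of these compounds alone.

Compound 1 `CS(=O)(=O)c1ccc(-c2nc3ccccn3c2Sc2ccccc2)cc1`: > 100000 nM (a limit)
Compound 2 `CCc1ccc(-c2nc3ccccn3c2Sc2ccccc2)cc1`: > 100000 nM (a limit)
Compound 3 `N#Cc1ccc(-c2nc3ccccn3c2Sc2ccccc2)cc1`: > 100000 nM (a limit)

All three compounds were tested in an ADME assay on NIH3T3 cells (Mus musculus) for inhibition, read by MTT assay, with a stated time of 48 h; a lower number here means a stronger inhibitor, a higher number a weaker inhibitor. In this assay compound 3 has no number of its own, only the limit > 100000 nM. The other two compounds stand at the same mark, so the measured set offers a single reading: the limit of > 100000 nM in this assay, at which 3 of the 3 values shown sit.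

Compound 4 `Clc1ccc(-c2nc3ccccn3c2Sc2ccccc2)cc1` differs from compound 3 in one place: chloro in place of cyano on an aromatic carbon. The change turns 4-cyanophenyl into 4-chlorophenyl.

Going by the values given here, three measured steps bear on this change, and all of them alter the group at this same place: a step that the two limits leave unreadable from compound 1 to compound 2, a step that the two limits leave unreadable from compound 1 to compound 3 and a step that the two limits leave unreadable from compound 2 to compound 3. None of them has a readable size. Methylsulfonyl, ethyl and cyano all leave the reading at the limit, but chloro itself has not been seen in this series. From compound 3, with a step that the two limits leave unreadable from compound 2 to compound 3 as its nearest guide, no step beyond the scatter is expected in this assay, and no direction can be named.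

The estimated step is a number no higher from compound 3 to compound 4 (the limit leaves the size open). Compound 4 is expected at 100000 nM, with an estimated range from 40000 nM to 200000 nM.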

Compound 4, half-maximal inhibitory concentration: > 100000 nM
Compound 4: only a limit was reported; the forecaster's own chance of this, stated with the estimate: 85%; the middle value sits exactly at the limit.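

In this assay compound 4 gives > 100000 nM, which is a limit and not a number. The steps joining compound 4 to compound 1, compound 2 and compound 3 therefore cannot be read, and the set stands at a single reading: the limit of > 100000 nM in this assay, at which 4 of the 4 values shown sit.

The compounds shown leave open whether any group at this place gives a readable value.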